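Amino for nitro on a weak beta-lactam antiproliferative

A few compounds are considered here, and "the series" means these few. Any claim that something is new, unique, unknown or untested is made for them only; others in the source may bear on it.

Measured compounds:
- compound 1, `COc1ccc([C@@H]2[C@H](Oc3ccccc3)C(=O)N2c2cc(OC)c(OC)c(OC)c2)cc1[N+](=O)[O-]`: 69000 nM
- compound 2, `COc1ccc([C@@H]2[C@@H](Oc3ccccc3)C(=O)N2c2cc(OC)c(OC)c(OC)c2)cc1[N+](=O)[O-]`: 4100 nM
- compound 3, `COc1ccc(N2C(=O)[C@@H](Oc3ccccc3)[C@H]2c2ccc(OC)c(O)c2)cc1`: 49000 nM

Compound 1 gives the highest number of the three in a functional assay on MCF7 cells (Homo sapiens) for antiproliferative activity, read by MTT assay, with stated times of 24 h and 72 h; a lower number here means a stronger inhibitor, a higher number a weaker inhibitor. Its nearest neighbour on the numbers is compound 3, whose value lies within the scatter of that of compound 1, so the two cannot be ordered. The furthest is compound 2, reached by a 17-fold lower number from compound 1 to compound 2 (1.23 log units; beyond the scatter), a large step that rests on (the fact that compounds 1 and 2 differ only in the configuration as drawn).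

The step under consideration leads from compound 1 to compound 4, `COc1ccc([C@@H]2[C@H](Oc3ccccc3)C(=O)N2c2cc(OC)c(OC)c(OC)c2)cc1N`. The change is amino in place of nitro on an aromatic carbon of the ring that carries the methoxy group. Among the compounds with values here, no measured pair shows this exchange: the only measured step that is a single change, from compound 1 to compound 2, concerns configuration alone, and compound 3 differs from compound 1 in more than one place, so its value speaks only for itself. The expectation for compound 4 therefore rests on the standing of compound 1 and on the size of the step already seen, and is held loose: a moderate movement toward a lower number is expected, a 2.0-fold lower number from compound 1 to compound 4 (0.29 log units; within the scatter), but nothing in the data forces it beyond the scatter. Compound 4 is estimated at 35000 nM, with a range from 6000 nM to 200000 nM.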

Compound 4, half-maximal inhibitory concentration: 12200 nM
Beside the measured number, compound 4's estimate is 2.9-fold (0.46 log units) above it, and the stated range covers the measured number.
By their numbers in this assay, from the lowest: compound 2; then compound 4; then compounds 3 and 1 (each within the scatter of the next).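

In this assay, the place on an aromatic carbon ortho to a methoxy group proves sensitive to what it carries, and not only to the configuration of the shared core: amino in place of nitro gives a 5.7-fold lower number from compound 1 to compound 4 (0.75 log units; beyond the scatter), a modest step but one that lies beyond the scatter. Within the data shown here, this is the first change of a group at this place that can be read directly, since the only earlier single change was a 17-fold lower number from compound 1 to compound 2 (1.23 log units; beyond the scatter), a large step that altered configuration while leaving the nitro group in place, and the new exchange, 4-methoxy-3-nitrophenyl to 3-amino-4-methoxyphenyl, moves the number less far than that step did. Nothing in hand explains why the exchange has this effect.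

The compounds shown leave open whether amino in place of nitro would move the number in the same direction, or by a similar size, on the configuration of compound 2. They also leave open how other groups at this place, such as an acetamide or a dimethylamino group, would compare with the amino group of compound 4.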